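The compounds below may be only part of what the source reports. "The series", "measured", "known", "first", "only" and "open" are said of these compounds alone.

Measured in a functional assay on COLO 205 cells (Homo sapiens) for inhibition, read by sulforhodamine B assay; on this read-out lower numbers stand for stronger inhibition of growth and higher numbers for weaker inhibition of growth:

- Compound 1 `FC(F)(F)c1ccc(-c2ccc(-c3ccc(-c4nc5ccccc5[nH]4)cc3)cc2)cc1`: 33900 nM
- Compound 2 `FC(F)(F)Oc1ccc(-c2ccc(-c3ccc(-c4nc5ccccc5[nH]4)cc3)cc2)cc1`: 100000 nM
- Compound 3 `COc1ccc(-c2ccc(-c3ccc(-c4nc5ccccc5[nH]4)cc3)cc2)cc1`: 45200 nM

Compound 2 is the weakest of the three, with the highest number, and its steps to both others lie beyond the scatter. Compound 4 `Cc1ccc2[nH]c(-c3ccc(-c4ccc(-c5ccc(OC(F)(F)F)cc5)cc4)cc3)nc2c1` differs from it in one place: methyl in place of hydrogen on an aromatic carbon. This is methyl in place of hydrogen on an aromatic carbon, turning 1H-benzimidazol-2-yl into 5-methyl-1H-benzimidazol-2-yl.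

For the measured compounds named here, no measured step touches that place, so the evidence is only indirect. All three steps swap a different group: a 2.9-fold higher number from compound 1 to compound 2 (0.47 log units; beyond the scatter) and a 2.2-fold lower number from compound 2 to compound 3 (0.34 log units; beyond the scatter) are modest, while a 1.3-fold higher number from compound 1 to compound 3 (0.12 log units; within the scatter) stays within the scatter. Going by the values given here, with steps this small as the only guide, no step beyond the scatter is expected in this assay. Since compound 2 already stands at 100000 nM, any drift is expected to be towards a lower number. The expected step is a 1.7-fold lower number from compound 2 to compound 4 (0.22 log units; within the scatter). The estimate for compound 4 is 60000 nM, with an expected range from 25000 nM to 100000 nM.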

Compound 4, concentration for 50% growth inhibition: 30600 nM
The estimate for compound 4 lay 2.0-fold (0.29 log units) above the measured number; measured number inside the range.
By their numbers in this assay, from the lowest: compounds 4, 1 and 3 (each within the scatter of the next); then compound 2.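

Turning 1H-benzimidazol-2-yl into 5-methyl-1H-benzimidazol-2-yl gives a 3.3-fold lower number from compound 2 to compound 4 (0.51 log units; beyond the scatter) in this assay. For the compounds shown here, the earlier steps only swapped the trifluoromethyl, trifluoromethoxy and methoxy groups, so this is the first sign that a change at this aromatic carbon can also shift the number, and that a single added methyl is enough to do so, at least when trifluoromethoxy is present. No measurement here gives a reason for this modest drop.

From the compounds shown here alone, it remains open whether another group on this carbon, such as ethyl, chlorine or an amine, would move the number further, not at all, or the opposite way. Going by these compounds, it also remains open whether the same methyl would give a similar step in the trifluoromethyl or methoxy compounds.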